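Amide substituent swap on the shared benzoxazolone-type core

This account rests on a few compounds, and the source may have more. Where it says the series, first, only, none or still open, it means among the compounds named here.

Two compounds of this series carry a measurement in an ADME assay on RAW264.7 cells (Mus musculus) for cytotoxicity, read by MTT assay, with a stated time of 72 h, tested at 50 uM; on this read-out higher numbers stand for a stronger effect at the one concentration tested and lower numbers for a weaker effect. Compound 1 `O=C(Cn1c(=O)oc2cc([N+](=O)[O-])ccc21)Nc1ccccn1` gives 38.6% in this assay. Compound 2 `O=C(Cn1c(=O)oc2ccccc21)NCc1cccs1` gives 23.4% in this assay, the lower of the two numbers; its nearest neighbour is compound 1, whose number lies higher by a margin beyond the usual scatter of this read-out.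

Compound 3 `O=C(Cn1c(=O)oc2ccccc21)Nc1ccccn1` is not yet measured. It differs from compound 2 in one place: pyridin-2-yl in place of (thiophen-2-yl)methyl on an amide-type nitrogen. Among the compounds with values here, no pair of measured compounds differing in only this place exists, so the size of this step has to be judged from the two numbers at hand. Compound 1 shares the pyridin-2-yl amide with compound 3 and stands higher than compound 2, but compound 1 also differs from compound 3 in another place, so its value is only a loose guide.

For compound 3 the step from compound 2 is expected to be a modest rise, a number 6.6 percentage points higher from compound 2 to compound 3 (within the scatter), possibly no more than the scatter. Compound 3 is therefore estimated at 30% in this assay, within a range of 15% to 45%.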

Compound 3, a percentage reported as inhibition, at one concentration (the size of the read-out at that concentration, not a potency): 20.2%
For compound 3 the middle estimate is 9.8 percentage points above the measured one; measured number inside the range.
By their numbers in this assay, from the lowest: compounds 3 and 2 (each within the scatter of the next); then compound 1.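

In this assay, the change of (thiophen-2-yl)methyl to pyridin-2-yl on the amide-type nitrogen gives a number 3.2 percentage points lower from compound 2 to compound 3 (within the scatter) on the unsubstituted shared core, so this read-out does not separate these two amide substituents. The nitro group on the aromatic carbon does mark a separation: replacing it with hydrogen while keeping the pyridin-2-yl amide gives a number 18.4 percentage points lower from compound 1 to compound 3 (beyond the scatter) and ties the higher number of compound 1 to the nitro group in this matched pair, not to the amide substituent it shares with compound 3. The size of this nitro step is known in the pyridin-2-yl amide only, and no separate data here account for either step.

Going by these compounds, it remains open whether the nitro step carries over to the (thiophen-2-yl)methyl amide, or whether an amine or a carboxylic acid on the same aromatic carbon would give a number closer to compound 1 or to compound 3. The compounds shown also leave open how a longer chain or a simple methyl group on the amide-type nitrogen would compare with pyridin-2-yl and (thiophen-2-yl)methyl.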